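The source may report more compounds than this note shows. Statements on the series, on what has been measured and on what is new or still open speak of the compounds shown alone.

Working notes on the series.

Three compounds carry numbers in a functional assay for inhibition of Polyunsaturated fatty acid 5-lipoxygenase (Homo sapiens), in the absence of a further agent; a higher number here means a weaker inhibitor, a lower number a stronger inhibitor. Compound 1 `CCCc1cc(Cl)c2oc(Cc3ccc(OC)cc3)c(CCC)c2c1O` gives 20 nM, compound 2 `CCCc1cc(Cl)c2oc(Cc3ccc(Cl)cc3)c(C)c2c1O` gives 26 nM, and compound 3 `COc1ccc(Cc2oc3c(Cl)ccc(O)c3c2C)cc1` gives 376 nM. Compound 3 stands highest of the three: its number lies above that of compound 2 and further still above that of compound 1, both gaps beyond the scatter, so compound 3 is the weakest inhibitor among those measured.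

Compound 4 `COc1ccc(Cc2oc3c(Cl)cc(CCC(=O)O)c(O)c3c2C)cc1` is not yet measured. It differs from compound 3 in one place, (2-carboxyethyl in place of hydrogen on an aromatic carbon), so a hydrogen on the core of compound 3 is replaced by a three-carbon chain ending in a carboxylic acid. Going by the values given here, no pair of measured compounds isolates this change, so no measured step can be quoted for it; the only guide is that the two compounds with a substituent other than hydrogen on that carbon, compound 1 and compound 2, give lower numbers than compound 3, though they differ from it elsewhere as well. A moderate step downward is expected, a 2.5-fold lower number from compound 3 to compound 4 (0.40 log units; beyond the scatter), and compound 4 is estimated at 150 nM, within a range from 40 nM to 600 nM.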

Compound 4, half-maximal inhibitory concentration: 2130 nM
Compound 4: the middle estimate sits 14-fold (1.15 log units) below what was measured, and the stated range ends below it.
By their numbers in this assay, from the lowest: compounds 1 and 2 (each within the scatter of the next); then compound 3; then compound 4.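

In this assay, going by these compounds alone, the first step that isolates a change at this aromatic carbon, ortho to a hydroxy group, goes upward: a 5.7-fold higher number from compound 3 to compound 4 (0.75 log units; beyond the scatter). On the core of compound 3, then, 2-carboxyethyl in place of hydrogen gives a weaker inhibitor, and this single step is all that is known about substitution at this carbon. No measurement at hand bears on why the number rises.

From the compounds shown here alone, it remains open whether the rise follows the carboxylic acid or the chain that carries it; a methyl ester, a primary amide or a plain propyl chain at this carbon on the core of compound 3 would separate the two. Also open, going by these compounds, is whether the same step would hold on the cores of compound 1 and compound 2, which differ from compound 3 in more than one place.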